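The source may hold more compounds than are shown below. What is called first, only, known or untested is meant among the compounds shown, and "the series" means these compounds.

In a functional assay on MDA-MB-231 cells (Homo sapiens) for cytotoxicity, read by MTT assay, with a stated time of 72 h (on this read-out lower numbers stand for stronger inhibition and higher numbers for weaker inhibition), compound 1 `CCCCCCCCNc1nc(SCc2ccc(C(F)(F)F)cc2)nc2ccccc12` gives 22300 nM, the highest of the two numbers reported, though that standing rests on the step of a 1.2-fold lower number from compound 1 to compound 2 (0.08 log units; within the scatter), which is too small to separate the pair. Compound 2 `FC(F)(F)c1ccc(CSc2nc(Nc3ccccc3)c3ccccc3n2)cc1` gives 18400 nM in this assay. Compound 3 `COc1ccccc1Nc1nc(SCc2ccc(C(F)(F)F)cc2)nc2ccccc12` is recorded in this assay only as a limit, > 50000 nM. The steps of an at least 2.2-fold higher number from compound 1 to compound 3 (0.35 log units; beyond the scatter) and an at least 2.7-fold higher number from compound 2 to compound 3 (0.43 log units; beyond the scatter) are therefore bounded only on one side, because the limit of > 50000 nM in this assay, at which 1 of the 3 values shown sits, caps what can be said of them.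

Compound 4 `FC(F)(F)c1ccc(CSc2nc(Nc3cccc(Br)c3)c3ccccc3n2)cc1` differs from compound 1 by 3-bromophenyl in place of octyl on a nitrogen on an aromatic ring. Going by the values given here, the one measured step that bears directly on this change is the swap of the octyl chain for a ring, a 1.2-fold lower number from compound 1 to compound 2 (0.08 log units; within the scatter), which stayed within the scatter. Among the compounds with values here, no measured step shows what bromine on such a ring does in this assay. On that basis compound 4 is expected to show no step beyond the scatter, a 1.2-fold lower number from compound 1 to compound 4 (0.09 log units; within the scatter), and its estimated value in this assay is 18000 nM, with a range from 6000 nM to 50000 nM.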

Compound 4, half-maximal inhibitory concentration: 22100 nM
For compound 4 the middle estimate is 1.2-fold (0.09 log units) below the measured one; the measured number falls inside the stated range.
By their numbers in this assay, from the lowest: compounds 2, 4 and 1 (each within the scatter of the next). At a limit, above all of these: compound 3.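

In this assay, adding bromine to the phenyl ring produces no change that can be distinguished from the scatter: a 1.2-fold higher number from compound 2 to compound 4 (0.08 log units; within the scatter). A second ring-bearing compound also stands level with the octyl chain, a 1.0-fold lower number from compound 1 to compound 4 (0.00 log units; within the scatter), so on this nitrogen neither the 3-bromophenyl group nor the unsubstituted phenyl group can be told apart from octyl. The 2-methoxyphenyl group alone stands apart, an at least 2.2-fold lower number from compound 3 to compound 4 (0.35 log units; beyond the scatter), but this step is bounded on one side only: the limit of > 50000 nM in this assay, at which 1 of the 4 values shown sits.

Going by these compounds, whether that separation comes from the methoxy group itself or from where it sits on the ring stays open. So does whether an amine or a carboxylic acid on the phenyl ring, or a chain longer than octyl on the nitrogen, would move the number away from this level.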